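Swapping the Nitrile of Compound 2 for a Dimethylamide

The compounds below may be only part of what the source reports. "The series", "measured", "known", "first", "only" and "open" are said of these compounds alone.

Among the compounds with values here, compound 2 `CNCc1cc(C#N)ccc1Oc1ccc(Cl)cc1Cl` is the only compound here that gives a number in an assay on HEK293 cells for inhibition of sodium-dependent dopamine transporter (Homo sapiens); a lower number here means a stronger inhibitor, a higher number a weaker inhibitor: compound 2 gives 3010 nM. Compound 1 `CNCc1cc(C#N)ccc1Oc1ccc(Cl)cc1OC` carries methoxy where compound 2 carries chloro, and in this assay compound 1 gives only a limit, > 40000 nM. Within the data shown here, the one measured step, an at least 13-fold lower number from compound 1 to compound 2 (1.12 log units; beyond the scatter), is large, though one of its ends is the limit of > 40000 nM in this assay, at which 1 of the 2 values shown sits. Compound 3 `CNCc1cc(C(=O)N(C)C)ccc1Oc1ccc(Cl)cc1Cl` differs from compound 2 at another position: dimethylcarbamoyl in place of cyano on an aromatic carbon. Among the measured compounds shown here, no measured step touches that position, so the chloro-for-methoxy change offers no direct guide to it, and the expected change is held modest and uncertain. The expected step of a 2.0-fold higher number from compound 2 to compound 3 (0.30 log units; within the scatter) is a mild weakening that could still fall within the usual scatter. Compound 3 is therefore estimated at 6000 nM in this assay, with a range from 1500 nM to 25000 nM.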

Compound 3, half-maximal inhibitory concentration: 275 nM
Compound 3: the middle estimate sits 22-fold (1.34 log units) above what was measured; the whole stated range lies above it.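

Dimethylcarbamoyl in place of cyano gives an 11-fold lower number from compound 2 to compound 3 (1.04 log units; beyond the scatter) in this assay, which shows that this position, meta to the (methylamino)methyl group, also has a large effect on the number and accepts a group of 5 heavy atoms where cyano has 2. The two groups have the same counts of hydrogen-bond donors and acceptors and the same net charge, so those counts do not separate compound 2 from compound 3. Nothing shown here gives a reason for the step.

The compounds shown leave open whether the step depends on the two methyl groups on the amide nitrogen, as an unsubstituted carboxamide, a diethylcarbamoyl group or a methyl ester at this position could tell. They also leave open whether dimethylcarbamoyl would have a similar effect with methoxy in place of chloro, as in compound 1.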